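Adding a Second Chlorine to the Aryl Ring

The compounds below may be only part of what the source reports. "The series", "measured", "known", "first", "only" and "open" are said of these compounds alone.

Compound 3 `CCO/C(O)=C1\C(COCCN2CC(=O)NC2=O)=NC(C)=C(C(=O)OC)C1c1ccccc1Cl` stands at the high end of the three measured numbers: in a functional assay (aorta) with Rattus norvegicus as the target (a lower number here means a stronger inhibitor, a higher number a weaker inhibitor), compound 3 gives 20 nM. Compound 1 `CCO/C(O)=C1\C(COCCn2ccnn2)=NC(C)=C(C(=O)OC)C1c1cccc(Cl)c1Cl` gives 5.01 nM in this assay, and compound 2 `CCO/C(O)=C1\C(COCCN2CC(=O)N(C)C2=O)=NC(C)=C(C(=O)OC)C1c1cccc(Cl)c1Cl` gives 5.01 nM; both lie a clear step below compound 3, beyond the usual scatter. Among the compounds with values here, the single measured step, no change at the digits printed from compound 1 to compound 2 (within the scatter), swaps the group at the end of the side chain and leaves the number unchanged, so that end of the molecule seems tolerant.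

Compound 4 `CCO/C(O)=C1\C(COCCN2CC(=O)NC2=O)=NC(C)=C(C(=O)OC)C1c1cccc(Cl)c1Cl` is compound 3 with one change: chloro in place of hydrogen on an aromatic carbon, on an aromatic carbon of the six-membered carbon-only ring, ortho to a chloro group and meta to a large group. Within the data shown here, no measured step covers this change directly. Even so, compounds 1 and 2, which already carry the 2,3-dichlorophenyl that compound 4 gains, both sit at lower numbers than compound 3, and the side-chain end made no difference in no change at the digits printed from compound 1 to compound 2 (within the scatter). Compound 4 is therefore expected to move down toward those values, by a 3.3-fold lower number from compound 3 to compound 4 (0.52 log units; beyond the scatter). The estimate for compound 4 is 6 nM, with a range from 2.5 nM to 15 nM.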

Compound 4, half-maximal inhibitory concentration: 3.16 nM
Compound 4: the middle estimate sits 1.9-fold (0.28 log units) above what was measured; the measured number falls inside the stated range.
By their numbers in this assay, from the lowest: compounds 4, 1 and 2 (each within the scatter of the next); then compound 3.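

In this assay, a direct comparison with the rest of the molecule held fixed now shows that going from 2-chlorophenyl to 2,3-dichlorophenyl matters (a 6.3-fold lower number from compound 3 to compound 4 (0.80 log units; beyond the scatter)). With the 2,3-dichlorophenyl in place, the far end of the side chain again makes no difference beyond the scatter, both for hydrogen in place of methyl on the amide-type nitrogen (a 1.6-fold lower number from compound 2 to compound 4 (0.20 log units; within the scatter)) and for 2,4-dioxoimidazolidin-1-yl in place of 1H-1,2,3-triazol-1-yl (a 1.6-fold lower number from compound 1 to compound 4 (0.20 log units; within the scatter)). Nothing measured here explains the effect of the added chlorine.

The compounds shown leave open whether a group such as methyl, methoxy or fluoro would serve as well as chloro at this aromatic carbon. They also leave open whether the side-chain end would remain as tolerant with an amine, a carboxylic acid or a longer chain.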